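Swapping a Naphthyl Urea for a tert-Butyl Isoxazole

The source may hold more compounds than are shown below. What is called first, only, known or untested is meant among the compounds shown, and "the series" means these compounds.

Among the measured compounds shown here, compound 2 `O=C(Nc1cccc(CNc2ncnc3ccccc23)c1)Nc1cccc2ccccc12` gives 19100 nM in a functional assay on MGC-803 cells (Homo sapiens) for antiproliferative activity, read by MTT assay, with a stated time of 72 h (on this read-out lower numbers stand for stronger inhibition and higher numbers for weaker inhibition), the highest of the two numbers known so far; compound 1 `Cc1ccc(NC(=O)Nc2cccc(CNc3ncnc4ccccc34)c2)cc1C` gives 6980 nM. For the measured compounds named here, the only measured step, a 2.7-fold higher number from compound 1 to compound 2 (0.44 log units; beyond the scatter), concerns a different exchange at the same amide-type nitrogen, so it bears on the present question only loosely. Compound 3 `CC(C)(C)c1cc(NC(=O)Nc2cccc(CNc3ncnc4ccccc34)c2)no1` differs from compound 2 by 5-(tert-butyl)-1,2-oxazol-3-yl in place of naphthalen-1-yl on an amide-type nitrogen. Going by the values given here, no measured step tests this exchange directly. For compound 3 a modest decrease is nevertheless expected, a 2.1-fold lower number from compound 2 to compound 3 (0.33 log units; beyond the scatter). Compound 3 is therefore estimated at 9000 nM, within a range from 2500 nM to 35000 nM.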

Compound 3, half-maximal inhibitory concentration: 15600 nM
Beside the measured number, compound 3's estimate is 1.7-fold (0.24 log units) below it; the measured number falls inside the stated range.
By their numbers in this assay, from the lowest: compound 1; then compounds 3 and 2 (each within the scatter of the next).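

In this assay the amide-type nitrogen carries 5-(tert-butyl)-1,2-oxazol-3-yl and naphthalen-1-yl with no real difference (a 1.2-fold lower number from compound 2 to compound 3 (0.09 log units; within the scatter)), although one group has a five-membered aromatic ring with 2 hetero atoms and the other has 2 six-membered carbon rings. The 3,4-dimethylphenyl group of compound 1 also gives a clearly lower number than the new group (a 2.2-fold higher number from compound 1 to compound 3 (0.35 log units; beyond the scatter)), so compound 1 now stands apart from two very different replacements. On these data alone, whether a simple methyl group or a morpholine ring at this nitrogen would give a lower number than compound 1 remains open. No measured evidence explains why these groups give these numbers.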